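The source may report more compounds than this note shows. Statements on the series, on what has been measured and on what is new or still open speak of the compounds shown alone.

Working notes on the series: compound 1 (`COc1c(N2C[C@H]3CCCN(Cc4cn(CCCN5C(=O)/C(=N/O)c6cc(C)ccc65)nn4)[C@H]3C2)c(F)cc2c(=O)c(C(=O)O)cn(C3CC3)c12`) and compound 2 (`COc1c(N2C[C@H]3CCCN(Cc4cn(CCCN5C(=O)C(=O)c6cc(C)ccc65)nn4)[C@H]3C2)c(F)cc2c(=O)c(C(=O)O)cn(C3CC3)c12`) are the two measured points in an ADME assay on Vero cells (Chlorocebus sabaeus) for cytotoxicity, read by MTT assay, with a stated time of 72 h (a lower number here means that less compound is tolerated, a higher number that more compound is tolerated), so far. Here compound 1 gives 8 ug/mL and compound 2 gives 32 ug/mL, which places compound 2 highest of the two, beyond the scatter. Compound 3 (`COc1c(N2C[C@H]3CCCN(Cc4cn(CCCN5C(=O)/C(=N/O)c6ccccc65)nn4)[C@H]3C2)c(F)cc2c(=O)c(C(=O)O)cn(C3CC3)c12`) has not yet been measured. Its structural change from compound 2 is as follows: a group of 12 heavy atoms (8 carbon, 2 nitrogen, 2 oxygen; one five-membered non-aromatic ring with 1 hetero atom, one six-membered aromatic ring of carbon only) in place of a group of 12 heavy atoms (9 carbon, 1 nitrogen, 2 oxygen; one five-membered non-aromatic ring with 1 hetero atom, one six-membered aromatic ring of carbon only), on a saturated chain carbon, three bonds along the chain from an aromatic nitrogen. For the measured compounds named here, no measured step isolates this change. Structurally, compound 3 stands nearer to compound 1, which gives 8 ug/mL, so a move to a lower number in this assay is expected, beyond the scatter. The expected step is a 3.2-fold lower number from compound 2 to compound 3 (0.51 log units; beyond the scatter), though with only two measured points this remains a rough estimate. The expected value for compound 3 is 10 ug/mL, with an estimated range of 4 ug/mL to 24 ug/mL.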

Compound 3, half-maximal cytotoxic concentration: 8 ug/mL
The estimate for compound 3 lay 1.3-fold (0.10 log units) above the measured number; low and high end bracket the measured number.
By their numbers in this assay, from the lowest: compounds 1 and 3 (each within the scatter of the next); then compound 2.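

In this assay, hydrogen in place of methyl on an aromatic carbon gives no change at the digits printed from compound 1 to compound 3 (within the scatter) and so, in this pair, the methyl group has no readable effect on how much compound is tolerated. For the compounds shown here, the exchange of the whole group on the saturated chain carbon, three bonds along the chain from an aromatic nitrogen, gives a 4.0-fold lower number from compound 2 to compound 3 (0.60 log units; beyond the scatter) and so stays beyond the scatter even without the methyl group, although no single pair isolates the remaining difference within that group. Nothing available explains either result.
On these data alone, it remains open whether a chlorine atom or a methoxy group on the same aromatic carbon would also leave the number within the scatter. Also open, as far as these compounds go, is whether hydrogen in place of methyl would be equally silent in the group carried by compound 2, or with a longer chain to the aromatic nitrogen.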